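Iodo to ethynyl on compound 1

A few compounds are considered here, and "the series" means these few. Any claim that something is new, unique, unknown or untested is made for them only; others in the source may bear on it.

Measured in a functional assay on CCRF-SB cells (Homo sapiens); a higher number here means a weaker inhibitor, a lower number a stronger inhibitor:
Compound 1 `NC(=O)c1nn([C@@H]2O[C@H](CO)[C@@H](O)[C@H]2O)cc1I`: > 300000 nM
Compound 2 `COC(=O)c1nn([C@@H]2O[C@H](CO)[C@@H](O)[C@H]2O)cc1I`: 900 nM

In this assay compound 1 gives > 300000 nM, which is a limit of the assay and not a number. Compound 3 `C#Cc1cn([C@@H]2O[C@H](CO)[C@@H](O)[C@H]2O)nc1C(N)=O` keeps the carbamoyl group of compound 1 and differs from it in one place: ethynyl in place of iodo on an aromatic carbon. For the measured compounds named here, no measured step touches the iodo group. Going by the values given here, the only measured step, an at least 330-fold lower number from compound 1 to compound 2 (2.52 log units; beyond the scatter), is large, but it acts on a carbonyl carbon, so it bears on this change only indirectly. It shows that a single change to the core of compound 1 can move the result in this assay a long way. A moderate move towards a lower number is therefore expected, with wide uncertainty. The estimated step is an at least 10-fold lower number from compound 1 to compound 3 (1.00 log units; beyond the scatter). For compound 3 the estimate is 30000 nM, with an expected range of 2000 nM to 300000 nM.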

Compound 3, half-maximal inhibitory concentration: > 300000 nM
Compound 3: only a limit was reported; the forecaster's own chance of this, stated with the estimate: 30%; at least 10-fold (1.00 log units) between middle value and limit.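

In this assay compound 3 gives > 300000 nM, which is a limit of the assay and not a number. For the compounds shown here, compound 1 also stands at a limit, so no step between compound 1 and compound 3 can be read: the limit of > 300000 nM in this assay, at which 2 of the 3 values shown sit. From the compounds shown here alone, whether ethynyl or iodo gives the lower number on the shared core remains open.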